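The source may hold more compounds than are shown below. What is called first, only, known or untested is meant among the compounds shown, and "the series" means these compounds.

Of the compounds shown here, three have been read in a functional assay on HCT-116 cells (Homo sapiens) for antiproliferative activity, read by MTT assay, with a stated time of 48 h; a higher number here means a weaker inhibitor, a lower number a stronger inhibitor. Compound 1 (`CCCCCC(CCO)n1cnc2c(N)nc(Cl)nc21`) is reported only as a limit (> 50000 nM). Going by the values given here, compound 2 (`CCCCCCC(CCO)n1cnc2c(Cl)nc(Cl)nc21`) gives the only actual number so far (12100 nM). Compound 3 (`CCCCCCC(CCO)n1cnc2c(N)ncnc21`) is likewise reported only as a limit (> 50000 nM). Compound 3 therefore stands at the limit of > 50000 nM in this assay, at which 2 of the 3 values shown sit, and offers no exact starting number.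

The step of interest leads to compound 4 (`CCCCCCC(CCO)n1cnc2c(N)nc(Cl)nc21`), with chloro in place of hydrogen on an aromatic carbon, between two ring nitrogen atoms (chloro in place of hydrogen on an aromatic carbon). Among the compounds with values here, no measured pair isolates this change, so any forecast is loose. A modest move toward a lower number in this assay is expected, and a result that remains at the limit would be quite possible. The hope of a number rests on compound 2 (12100 nM), which shows that this series can register in this assay. The caution rests on compound 1, which is a limit (> 50000 nM).

The expected change is small (an at least 1.4-fold lower number from compound 3 to compound 4 (0.15 log units; that floor lies within the scatter)). For compound 4 the estimated value is 35000 nM with an expected range from 14000 nM to 70000 nM.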

Compound 4, half-maximal inhibitory concentration: > 50000 nM
Compound 4 was reported as a limit; the forecaster's own chance of this, stated with the estimate: 50%; at least 1.4-fold (0.15 log units) between middle value and limit.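

In this assay compound 4 is a limit and not a number, so chloro in place of hydrogen on this aromatic carbon, between two ring nitrogen atoms, gives no readable gain over the amino compound without chloro, and the series stays largely at the limit: the limit of > 50000 nM in this assay, at which 3 of the 4 values shown sit.

Going by these compounds alone, the only readable step is an at least 4.1-fold higher number from compound 2 to compound 4 (0.61 log units; beyond the scatter), for amino in place of chloro on an aromatic carbon, with the chloro between two ring nitrogen atoms present in both compounds; that chloro alone therefore does not bring a measurable value in this assay, and among the four compounds only compound 2, without the amino group, gives a number. The steps that join compound 4 to compound 3 and to compound 1 link two limits and cannot be read.

From the compounds shown here alone, whether chloro at this position changes anything beyond the limit stays open, since neither compound of that pair gives a number. Also open, going by these compounds, is whether a methoxy or a methylamino group in place of the amino group, or bromo in place of the chloro between two ring nitrogen atoms, would bring a number in this assay.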